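Branching the Acetamido Side Chain Toward a Tert-Butyl

A few compounds are considered here, and "the series" means these few. Any claim that something is new, unique, unknown or untested is made for them only; others in the source may bear on it.

compound 1, `CC(=O)N[C@@H](C)C(=O)NCc1ccc(OCc2cccc(F)c2)cc1`: > 300 mg/kg
compound 2, `CC(=O)N[C@@H](C(=O)NCc1ccc(OCc2cccc(F)c2)cc1)C(C)C`: > 300 mg/kg

Of the compounds shown here, two built on the shared core have been tested in a functional assay on the whole organism (strain albino) for inhibition, with Mus musculus as the target, in the maximal electroshock model, with a stated time of 4 h; a lower number here means that less compound is needed, a higher number that more compound is needed for the effect. Compound 1 `CC(=O)N[C@@H](C)C(=O)NCc1ccc(OCc2cccc(F)c2)cc1` gives only a limit of the assay there, > 300 mg/kg, not a number. Compound 2 `CC(=O)N[C@@H](C(=O)NCc1ccc(OCc2cccc(F)c2)cc1)C(C)C` likewise gives only a limit in this assay, > 300 mg/kg. Because of the limit of > 300 mg/kg in this assay, at which 2 of the 2 values shown sit, the step that the two limits leave unreadable from compound 1 to compound 2 cannot be read in size or direction: both ends of it sit at the same limit, so compound 2 stands on no number at all, only on a limit shared with compound 1.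

Compound 3 `CC(=O)N[C@@H](C(=O)NCc1ccc(OCc2cccc(F)c2)cc1)C(C)(C)C` differs from compound 2 by methyl in place of hydrogen on a saturated chain carbon bound to three saturated chain carbons. For the measured compounds named here, the only measured step that bears on this change is a step that the two limits leave unreadable from compound 1 to compound 2, and it is unreadable; no measured step of known size exists for it. The step that the limit leaves unreadable from compound 2 to compound 3 is therefore expected to be small or to remain hidden at the limit. Compound 3 is estimated to give 400 mg/kg in this assay, within a range from 150 mg/kg to 1500 mg/kg, with a limit rather than a number the more likely outcome.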

Compound 3, dose for half-maximal effect: > 300 mg/kg
Compound 3: only a limit was reported; the forecaster's own chance of this, stated with the estimate: 80%; the middle value lies beyond the limit too.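

Compound 3, like compound 1 and compound 2, gives a limit and not a number, so no step among these three compounds can be read in size or direction: the limit of > 300 mg/kg in this assay, at which 3 of the 3 values shown sit. Going by these compounds, whether going from 1-acetamidoethyl through 1-acetamido-2-methylpropyl to 1-acetamido-2,2-dimethylpropyl alters the dose needed in this assay stays open.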